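Phenyl to methoxymethyl swap across two cores

The source may hold more compounds than are shown below. What is called first, only, known or untested is meant among the compounds shown, and "the series" means these compounds.

Measured so far in an assay on HEK293 cells for antagonist activity at Neuronal acetylcholine receptor; alpha3/beta4 (Rattus norvegicus), read by FLIPR, using a membrane potential dye; on this read-out higher numbers stand for weaker inhibition and lower numbers for stronger inhibition:
compound 1 `CN1CC[C@@H]2CC[C@H](OCc3ccccc3)C[C@@H]21` gives > 300000 nM, a limit of the assay.
compound 2 `COCCO[C@H]1CC[C@H]2CCN(C)[C@H]2C1` gives > 300000 nM, a limit of the assay.
compound 3 `CN1CCC2=CC[C@H](OCc3ccccc3)C[C@@H]21` gives > 300000 nM, a limit of the assay.

Compound 1 and compound 2 differ by methoxymethyl in place of phenyl on a saturated chain carbon bound to an oxygen on a saturated carbon. Both values sit at the limit of > 300000 nM in this assay, at which 3 of the 3 values shown sit, so the step that the two limits leave unreadable from compound 1 to compound 2 cannot be read from these data. Compound 3 carries the same phenyl ether on another core; the difference between the two cores is not broken down here. Compound 4 `COCCO[C@H]1CC=C2CCN(C)[C@H]2C1` is not yet measured. Compound 3 and compound 4 differ by methoxymethyl in place of phenyl on a saturated chain carbon bound to an oxygen on a saturated carbon, the same change as made from compound 1 to compound 2. The earlier matched step was unreadable and compound 3 itself sits at a limit, so the step of a number no higher from compound 3 to compound 4 (the limit leaves the size open) is expected to be about nil. Compound 4 is estimated at 300000 nM, most probably reported again only as a limit.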

Compound 4, half-maximal inhibitory concentration: > 300000 nM
Compound 4: a limit, no number; the forecaster's own chance of this, stated with the estimate: 90%; the middle value sits exactly at the limit.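

Among these compounds, compound 3 and compound 4 both stand only as limits of the assay, so no step between them can be read. The compounds shown leave open how the phenyl and methoxymethyl ethers, or the two cores, compare in potency.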